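A Methyl Moved Around the Anilino Ring

The compounds below may be only part of what the source reports. "The series", "measured", "known", "first", "only" and "open" are said of these compounds alone.

Compound 1 `COc1cccc(/C=C/C(=O)c2sc(Nc3cccc(C)c3)nc2C)c1` stands at a limit of the assay. In a functional assay on Bel-7402 cells (Homo sapiens) for cytotoxicity, read by MTT assay (on this read-out higher numbers stand for weaker inhibition and lower numbers for stronger inhibition), compound 1 gives > 25000 nM, a limit rather than a number. Compound 2 `Cc1cccc(Nc2nc(C)c(C(=O)/C=C/c3ccc(Cl)cc3)s2)c1` gives > 25000 nM in this assay, again a limit. The step that the two limits leave unreadable from compound 1 to compound 2 is thus unreadable, and the limit of > 25000 nM in this assay, at which 2 of the 2 values shown sit, is all the two values show. Compound 3 `COc1cccc(/C=C/C(=O)c2sc(Nc3ccc(C)cc3)nc2C)c1` differs from compound 1 by 4-methylphenyl in place of 3-methylphenyl on a nitrogen on an aromatic ring. Within the data shown here, no measured step bears on this change, so no size can be read from the data. Compound 3 is therefore expected to give 30000 nM, with a range from 8000 nM to 100000 nM, most likely again as a limit. The expected step that the limit leaves unreadable from compound 1 to compound 3 is none beyond the scatter.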

Compound 3, half-maximal inhibitory concentration: > 25000 nM
Compound 3: only a limit was reported (the forecaster's own chance of this, stated with the estimate: 80%); the middle value does not contradict the limit.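

No step can be read between compound 1 and compound 3, whose results in this assay are both limits. The compounds shown leave open what 4-methylphenyl in place of 3-methylphenyl does to cytotoxicity, as all of them share one limit: the limit of > 25000 nM in this assay, at which 3 of the 3 values shown sit.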